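A few compounds are considered here, and "the series" means these few. Any claim that something is new, unique, unknown or untested is made for them only; others in the source may bear on it.

Measured so far:
compound 1 `CN1CCN(c2ccc(Nc3ncc4nc(Nc5ccc(F)cc5)n(-c5cccc(NC(=O)CO)c5)c4n3)cc2)CC1` gives 7.5 nM in a functional assay on HCC827 cells (Homo sapiens) for antiproliferative activity, read by MTT assay, with a stated time of 72 h; a higher number here means a weaker inhibitor, a lower number a stronger inhibitor
compound 2 `CC(=O)N1CC[C@H](n2c(Nc3ccccc3)nc3cnc(Nc4ccc(N5CCN(C)CC5)cc4)nc32)C1` gives 260 nM in this assay

Compound 1 has the lowest of the two numbers; compound 2 is the nearest, and the gap between the two values lies beyond the scatter. The two structures differ in more than one place, so the gap is not tied to a single change.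

The unmeasured compound 3 `CN1CCN(c2ccc(Nc3ncc4nc(Nc5ccc(F)cc5)n([C@H]5CCN(S(=O)(=O)C6CC6)C5)c4n3)cc2)CC1` keeps the core and the (4-fluorophenyl)amino group of compound 1 and differs from it as follows: 1-(cyclopropylsulfonyl)pyrrolidin-3-yl in place of 3-(((hydroxymethyl)carbonyl)amino)phenyl on an aromatic nitrogen. The aromatic ring that leaves carries both hydrogen-bond donors; the entering group has none and brings a defined stereocentre.

Among the compounds with values here, with no single-change step between measured compounds, the direction rests on the structural change alone. Compound 2, which also bears a pyrrolidinyl group on the aromatic nitrogen, sits well above compound 1, but it differs in two places. A loss beyond the scatter is expected, of moderate size, and the step of a 5.3-fold higher number from compound 1 to compound 3 (0.73 log units; beyond the scatter) states the expected change. For compound 3 the estimate is 40 nM, within 10 nM to 160 nM.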

Compound 3, half-maximal inhibitory concentration: 7.5 nM
Compound 3: the middle estimate sits 5.3-fold (0.73 log units) above what was measured; measured number below the stated range.
By their numbers in this assay, from the lowest: compounds 1 and 3 (each within the scatter of the next); then compound 2.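

In this assay, within the data shown here, placing 1-(cyclopropylsulfonyl)pyrrolidin-3-yl on the aromatic nitrogen in place of 3-(((hydroxymethyl)carbonyl)amino)phenyl gives no change at the digits printed from compound 1 to compound 3 (within the scatter), the first step read at a single place. With the core and the (4-fluorophenyl)amino group held constant, this position accepts a non-aromatic sulfonylated ring in place of the aromatic ring without a change beyond the scatter, so neither the six-membered aromatic ring nor the hydrogen-bond donors of the leaving group are required for this read-out in this pair. No supporting measurement is available to explain why the two groups read alike.

The compounds shown leave open whether the cyclopropylsulfonyl group contributes to the value, as a pyrrolidine with a free ring amine or with a methylsulfonyl group in its place would test, and whether the opposite stereoisomer at the pyrrolidine reads the same. They also leave open how far this position extends to other groups, such as a simple cyclopentyl ring or a longer chain ending in an amine or a carboxylic acid.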